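The compounds below may be only part of what the source reports. "The series", "measured", "known", "first", "only" and "open" are said of these compounds alone.

Compound 1 `C/N=C(/NC#N)NCCCCn1nc(N(C)C)ccc1=O`: in a functional assay on the whole organism (stomach) with Rattus norvegicus as the target (on this read-out lower numbers stand for an effect already at smaller amounts and higher numbers for an effect only at larger amounts of compound), compound 1 gives > 100 mg/kg, which is a limit of the assay.
Compound 2 `CCC/N=C(/NC#N)NCCCCCn1nc(-c2ccccc2)ccc1=O`: in this assay compound 2 gives > 100 mg/kg, again a limit.
Compound 3 `C/N=C(/NC#N)NCCCCn1nc(-c2ccc(C)cc2)ccc1=O`: in this assay compound 3 gives > 100 mg/kg, again a limit.

Among the measured compounds shown here, compound 3 therefore stands where all values so far stand, namely at the limit of > 100 mg/kg in this assay, at which 3 of the 3 values shown sit. For the measured compounds named here, the single measured step, a step that the two limits leave unreadable from compound 1 to compound 3, is left unreadable by the two limits, so its size is unknown. Compound 4 `C/N=C(/NC#N)NCCCCn1nc(Nc2ccccc2)ccc1=O` differs from compound 3 by anilino in place of 4-methylphenyl on an aromatic carbon. With no readable step to lean on, compound 4 is expected to give 150 mg/kg in this assay, within 50 mg/kg to 500 mg/kg, most likely reported once more only as a limit. The expected step that the limit leaves unreadable from compound 3 to compound 4 is accordingly none beyond the scatter.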

Compound 4, dose for half-maximal effect: > 100 mg/kg
Compound 4 gave a limit, no number; the forecaster's own chance of this, stated with the estimate: 75%; the middle value lies beyond the limit too.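

Compound 4 also gives only a limit, so its steps from compound 3 and from compound 1 cannot be read: the limit of > 100 mg/kg in this assay, at which 4 of the 4 values shown sit.

The compounds shown leave open what dose of any of them gives a half-maximal effect in this assay and whether anilino, 4-methylphenyl or dimethylamino changes that dose.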